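The source may report more compounds than this note shows. Statements on the series, on what has been measured and on what is new or still open speak of the compounds shown alone.

In a functional assay on DU-145 cells (Homo sapiens) for antiproliferative activity, read by sulforhodamine B assay, with a stated time of 48 h (on this read-out lower numbers stand for stronger inhibition and higher numbers for weaker inhibition), compound 1 (`O=C1NCCN1c1ccc(S(=O)(=O)Nc2ccc3[nH]ccc3c2)cc1`) gives 1370 nM, and compound 2 (`Cc1cccc(NS(=O)(=O)c2ccc(N3CCNC3=O)cc2)c1`) gives 580 nM. Among the measured compounds shown here, compound 2 therefore holds the lower of the two numbers so far, and its gap to compound 1 lies beyond the usual scatter of repeated measurements. Compound 3 (`Cc1ccc(C)c(NS(=O)(=O)c2ccc(N3CCNC3=O)cc2)c1`) has not yet been measured, and it differs from compound 2 in a single place: methyl in place of hydrogen on an aromatic carbon. The new methyl sits ortho to a large group and para to a methyl group, so that 3-methylphenyl becomes 2,5-dimethylphenyl. For the measured compounds named here, no measured pair of compounds here shows what such a change does, so any forecast is uncertain and has to allow for movement either way. The change is small, so the expected outcome in this assay is a modest shift at most. The estimated change is a 1.3-fold lower number from compound 2 to compound 3 (0.11 log units; within the scatter), leaning slightly toward stronger inhibition and not expected to pass beyond the scatter. For compound 3 the estimated value is 450 nM, with an expected range from 150 nM to 1300 nM.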

Compound 3, half-maximal inhibitory concentration: 1610 nM
Beside the measured number, compound 3's estimate is 3.6-fold (0.55 log units) below it; the measured number lies above the stated range.
By their numbers in this assay, from the lowest: compound 2; then compounds 1 and 3 (each within the scatter of the next).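

In this assay, among the compounds shown here, the change from 3-methylphenyl to 2,5-dimethylphenyl gives a 2.8-fold higher number from compound 2 to compound 3 (0.44 log units; beyond the scatter) and so means weaker inhibition, the first direct reading of a change at this place on the ring. A single added methyl, just one heavy atom with no hydrogen-bond donors or acceptors, is therefore enough to move the number beyond the usual scatter, which shows that this ring carbon, ortho to a large group and para to a methyl group, is not indifferent to what it carries. Nothing measured alongside these compounds accounts for the rise, so the step stands as an observation without an explanation.

Going by these compounds, whether the loss is particular to methyl or would follow any group at this place remains open, and a fluorine, a hydroxyl or a methoxy group on the same ring carbon would help to separate those two readings. Also open, on these data alone, is what the methyl already present in compound 2 contributes, a question that a plain phenyl ring or a chlorine in its place would address.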